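Lengthening the chain of compound 3

The source may hold more compounds than are shown below. What is called first, only, known or untested is meant among the compounds shown, and "the series" means these compounds.

compound 1 `CCCCC(CCO)n1cnc2c(Cl)nc(F)nc21`: 13200 nM
compound 2 `CCCCC(CCO)n1cnc2c(Cl)ncnc21`: > 50000 nM, a limit
compound 3 `CCCCC(CCO)n1cnc2c(Cl)nc(Cl)nc21`: 30900 nM

In a functional assay on SW480 cells (Homo sapiens) for antiproliferative activity, read by MTT assay, with a stated time of 48 h (on this read-out higher numbers stand for weaker inhibition and lower numbers for stronger inhibition), compound 3 holds the higher of the two actual numbers, and the nearest is a 2.3-fold higher number from compound 1 to compound 3 (0.37 log units; beyond the scatter). Compound 2 gives only a limit.

Compound 4 `CCCCCC(CCO)n1cnc2c(Cl)nc(Cl)nc21` differs from compound 3 by methyl in place of hydrogen on a saturated chain carbon, five bonds along the chain from an aromatic nitrogen. The measured steps, an at least 3.7-fold higher number from compound 1 to compound 2 (0.57 log units; beyond the scatter), a 2.3-fold higher number from compound 1 to compound 3 (0.37 log units; beyond the scatter) and an at least 1.6-fold lower number from compound 2 to compound 3 (0.20 log units; that floor lies within the scatter), all change an aromatic carbon, so none gives a size for a chain change. No step beyond the scatter is therefore expected in this assay. The estimated change is a 1.1-fold lower number from compound 3 to compound 4 (0.06 log units; within the scatter). Compound 4 is expected at 27000 nM, with an estimated range of 12000 nM to 50000 nM.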

Compound 4, half-maximal inhibitory concentration: 6010 nM
The estimate for compound 4 lay 4.5-fold (0.65 log units) above the measured number; the measured number lies below the stated range.
By their numbers in this assay, from the lowest: compound 4; then compound 1; then compound 3. At a limit, above all of these: compound 2.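

In this assay, the saturated chain carbon five bonds along the chain from an aromatic nitrogen proves sensitive to a small change: methyl in place of hydrogen there gives a 5.1-fold lower number from compound 3 to compound 4 (0.71 log units; beyond the scatter). Among these compounds, all earlier steps changed an aromatic carbon, so this is the first size for a chain change, and it lies beyond the scatter. Nothing measured here bears on why the chain change has this size.

Still open, as far as these compounds go, is whether a longer chain at this place lowers the number further, or whether an amine there does the same. Also open, from the compounds shown here alone, is whether the same methyl change acts alike on compound 1 and compound 2.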